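The source may hold more compounds than are shown below. What is called first, only, known or untested is meant among the compounds shown, and "the series" means these compounds.

Measured in the series:
- compound 1, `O=S(=O)(c1ccccc1F)c1cn(C2CCNC2)c2ncccc12`: 2 nM
- compound 2, `CN1CCC(n2cc(S(=O)(=O)c3ccccc3)c3cccnc32)C1`: 2.5 nM

Both values come from an assay on HeLa cells for displacement of a labelled ligand from 5-hydroxytryptamine receptor 6 (Homo sapiens); a higher number here means a weaker inhibitor, a lower number a stronger inhibitor. Compound 2 has the higher of the two numbers, but compound 1 lies close enough that the two values sit within the scatter, so no order between them can be read from these data. For the measured compounds named here, they differ in more than one place, and no single step connecting them is available.

The next compound, compound 3, `CN1CCC(n2cc(S(=O)(=O)c3ccc(F)cc3)c3cccnc32)C1`, departs from compound 2 by one change: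

fluoro in place of hydrogen on an aromatic carbon

Nothing measured in the series speaks to this kind of change, so the expectation rests on the change alone. A single fluorine added to the phenyl ring is expected to move this assay little; the estimated step of no change at the digits printed from compound 2 to compound 3 (within the scatter) is expected to stay within the scatter, in no clear direction. For compound 3 the value is estimated at 2.5 nM, with a range from 1 nM to 6 nM.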

Compound 3, inhibition constant: 5 nM
Beside the measured number, compound 3's estimate is 2.0-fold (0.30 log units) below it; the measured number falls inside the stated range.
By their numbers in this assay, from the lowest: compounds 1, 2 and 3 (each within the scatter of the next, the first and the last beyond it).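

In this assay, for the compounds shown here, the change from phenyl to 4-fluorophenyl gives a 2.0-fold higher number from compound 2 to compound 3 (0.30 log units; within the scatter), the first step that can be read across a single change. A fluoro on this aromatic carbon, para to a large group, therefore leaves compound 3 at 5 nM, a number that cannot be separated from that of its parent, and this position accepts the one added atom without a change that can be read. No independent measurement bears on this step, and the data offer no account of it.

This single step says nothing about how far the position would accept a larger group. On these data alone, whether a chloro, a methoxy, a trifluoromethyl or an amine on the same carbon would give a step beyond the scatter stays open.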